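The source may report more compounds than this note shows. Statements on the series, on what has been measured and on what is new or still open speak of the compounds shown alone.

Compound 3 `CN(Cc1ccco1)C1CCN(CCCc2c[nH]c3ccc(-n4cnnc4)cc23)CC1` gives 89 nM in an assay on CHO cells for displacement of a labelled ligand from 5-hydroxytryptamine receptor 1B (Homo sapiens) (on this read-out lower numbers stand for stronger inhibition and higher numbers for weaker inhibition), the second highest of the three numbers shown. Going by the values given here, compound 1 `CN(Cc1ccc(S(C)(=O)=O)cc1)C1CCN(CCCc2c[nH]c3ccc(-n4cnnc4)cc23)CC1` gives 140 nM, and the step of a 1.6-fold lower number from compound 1 to compound 3 (0.20 log units; within the scatter) is the only measured change at the same place. Among the compounds with values here, compound 2 `CC(=O)Nc1ccc([C@H](C)NCC2CCN(CCCc3c[nH]c4ccc(-n5cnnc5)cc34)CC2)cc1` gives 9.3 nM but differs from compound 3 in more than one place, so no single step joins them. Compound 4 `O[C@@H]1Cc2ccccc2[C@H]1NC1CCN(CCCc2c[nH]c3ccc(-n4cnnc4)cc23)CC1` carries (2-hydroxy-2,3-dihydro-1H-inden-1-yl)amino in place of ((furan-2-yl)methyl)(methyl)amino on a saturated ring carbon. Within the data shown here, the one measured step at this place was small, and compound 2 shows that a secondary amine bearing two hydrogen-bond donors can sit at a lower number. Compound 4 is therefore expected to show a 2.2-fold lower number from compound 3 to compound 4 (0.35 log units; beyond the scatter), and its estimated value is 40 nM, in the range 10 nM to 160 nM.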

Compound 4, half-maximal inhibitory concentration: 210 nM
Compound 4: the middle estimate sits 5.3-fold (0.72 log units) below what was measured; the measured number lies above the stated range.
By their numbers in this assay, from the lowest: compound 2; then compounds 3, 1 and 4 (each within the scatter of the next, the first and the last beyond it).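

In this assay, putting (2-hydroxy-2,3-dihydro-1H-inden-1-yl)amino in place of ((furan-2-yl)methyl)(methyl)amino on the saturated ring carbon gives a 2.4-fold higher number from compound 3 to compound 4 (0.37 log units; beyond the scatter) and so moves the number beyond the scatter. The earlier step, a 1.6-fold lower number from compound 1 to compound 3 (0.20 log units; within the scatter), altered only the group on the chain carbon and stayed within it. No evidence bears on why the number rose here.

The compounds shown leave open whether the hydroxyl, the fused ring or the lost methyl carries this step. A plain (2,3-dihydro-1H-inden-1-yl)amino group would separate the hydroxyl from the ring.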